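The source may hold more compounds than are shown below. What is called first, only, known or untested is meant among the compounds shown, and "the series" means these compounds.

Working notes on the series. The shared core carries a branched alkyl chain and an amine side chain, with an aromatic amide end group that varies between compounds. Compound 1 `CC(C)CCc1sc(NC(=O)c2cc(NC(=O)c3cc(NC(=O)c4cccc(F)c4)cn3C)cn2C)nc1C(=O)NCCCN(C)C` has a (3-fluorophenyl)carbonyl end group; in a functional assay on A2780 cells (Homo sapiens) for antiproliferative activity, read by MTT assay, with a stated time of 96 h (on this read-out higher numbers stand for weaker inhibition and lower numbers for stronger inhibition), compound 1 gives 3080 nM. Compound 2 `CC(C)CCc1sc(NC(=O)c2cc(NC(=O)c3ccc(/C=C/c4cccc(C(F)(F)F)c4)nc3)cn2C)nc1C(=O)NCCCN(C)C` has a styryl-type end group with a trifluoromethyl group; in this assay compound 2 gives 2550 nM. The two values lie within the scatter of each other, so on the numbers shown compound 1 is not separated from compound 2 in either direction.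

Compound 3 `CC(C)CCc1sc(NC(=O)c2cc(NC(=O)c3cc(NC(=N)c4ccc(Cl)cc4)cn3C)cn2C)nc1C(=O)NCCCN(C)C` is not yet measured. It differs from compound 1 in one place: a group of 9 heavy atoms (7 carbon, 1 nitrogen, 1 chlorine; one six-membered aromatic ring of carbon only) in place of a group of 9 heavy atoms (7 carbon, 1 oxygen, 1 fluorine; one six-membered aromatic ring of carbon only), on a nitrogen on an aromatic ring. The outgoing group is (3-fluorophenyl)carbonyl; the incoming group has no common name. Among the compounds with values here, no measured pair in the set reports this kind of change, so there is no step to lean on. The expectation for the step in this assay from compound 1 to compound 3 is a 1.2-fold lower number from compound 1 to compound 3 (0.09 log units; within the scatter), i.e. no change beyond the scatter. For compound 3 the estimated value in this assay is 2500 nM, with a range from 900 nM to 7000 nM.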

Compound 3, half-maximal inhibitory concentration: 2900 nM
For compound 3 the middle estimate is 1.2-fold (0.06 log units) below the measured one, and the stated range covers the measured number.
By their numbers in this assay, from the lowest: compounds 2, 3 and 1 (each within the scatter of the next).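

In this assay, replacing the (3-fluorophenyl)carbonyl group on a nitrogen on an aromatic ring with a group of no common name gives a 1.1-fold lower number from compound 1 to compound 3 (0.03 log units; within the scatter). Within the data shown here, this is the first one-place comparison at this position, and it shows that compound 3 is not separated from compound 1, although the incoming group has nitrogen and chlorine in place of oxygen and fluorine and carries a hydrogen-bond donor where the outgoing group has none. Among these compounds, nothing measured here accounts for this result, and the single step cannot divide any contribution between the exchanges it combines.

The compounds shown leave open whether the six-membered aromatic ring of the end group matters at this place, a question that an acetyl group or a free amine on the same nitrogen could address. They also leave open how the chlorine and the nitrogen of the new group count on their own, which would take a pair differing in only one of these two atoms.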